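2,3-Dichlorophenyl in place of 4-hydroxyphenyl

The source may report more compounds than this note shows. Statements on the series, on what has been measured and on what is new or still open speak of the compounds shown alone.

In a functional assay on MCF7 cells (Homo sapiens) for cytotoxicity, read by MTT assay, with a stated time of 72 h (a lower number here means a stronger inhibitor, a higher number a weaker inhibitor), compound 2 `COc1cccc(/C=C2\CCC/C(=C\c3ccc(O)cc3)C2=O)c1OC` stands at > 20000 nM, which is a limit of the assay and not a number. Compound 1 `COc1cccc(/C=C2\CCC/C(=C\c3ccccc3Cl)C2=O)c1OC` gives 11300 nM. Among the compounds with values here, the only measured step, an at least 1.7-fold higher number from compound 1 to compound 2 (0.24 log units; that floor lies within the scatter), is the one that bears on the change here. Compound 3 `COc1cccc(/C=C2\CCC/C(=C\c3cccc(Cl)c3Cl)C2=O)c1OC` differs from compound 2 by 2,3-dichlorophenyl in place of 4-hydroxyphenyl on a double-bonded chain carbon bound to a double-bonded ring carbon. The 2,3-dichlorophenyl group returns chlorine to the phenyl ring, as in compound 1 at 11300 nM, so a modest move towards a lower number is expected. The expected step is an at least 2.2-fold lower number from compound 2 to compound 3 (0.34 log units; beyond the scatter). The estimate for compound 3 is 9000 nM, with an expected range of 3500 nM to 20000 nM.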

Compound 3, half-maximal inhibitory concentration: > 20000 nM
Compound 3 gave a limit, no number (the forecaster's own chance of this, stated with the estimate: 20%); middle value at least 2.2-fold (0.34 log units) away from the limit.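

In this assay, chloro in place of hydrogen on an aromatic carbon gives an at least 1.7-fold higher number from compound 1 to compound 3 (0.24 log units; that floor lies within the scatter), so the added chlorine has no effect that can be told from the scatter. Chlorine on the phenyl ring therefore does not by itself secure a readable number here: compound 2 and compound 3 both end at a limit of the assay, not a number. The step between them cannot be read because both sit at the same limit: the limit of > 20000 nM in this assay, at which 2 of the 3 values shown sit.

How far compound 1 lies from compound 3 remains unresolved. Also open, as far as these compounds go, is how a phenyl ring carrying an amine or a carboxylic acid would read at this position.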